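Adding Chlorine to the Phenyl Ring of a Potent Antagonist

This account rests on a few compounds, and the source may have more. Where it says the series, first, only, none or still open, it means among the compounds named here.

Compound 1 `Cc1ccc(N2CCN(CCCCOc3ccc4c(=O)cc(-c5ccccc5)oc4c3)CC2)cc1` gives 195 nM in a functional assay for antagonist activity at Adrenergic receptor alpha-1 (Rattus norvegicus); on this read-out higher numbers stand for weaker binding and lower numbers for tighter binding. Compound 2 `Cc1ccccc1N1CCN(CCCCOc2ccc3c(=O)cc(-c4ccccc4)oc3c2)CC1` differs only in the methylphenyl group on the ring nitrogen; in this assay compound 2 gives 19.5 nM, and the shift a 10-fold lower number from compound 1 to compound 2 (1.00 log units; beyond the scatter) places compound 2 at the tighter end of the two numbers measured. Compound 3 `Cc1ccccc1N1CCN(CCCCOc2ccc3c(=O)cc(-c4ccc(Cl)cc4)oc3c2)CC1` keeps that arrangement and introduces (chloro in place of hydrogen on an aromatic carbon). Among the compounds with values here, no measured step touches the phenyl on the far side of the shared core, so the measured change gives no direct guide. The expectation for compound 3 is therefore a step of a 1.0-fold higher number from compound 2 to compound 3 (0.01 log units; within the scatter) within the usual scatter. Compound 3 is estimated at 20 nM in this assay, between 6 nM and 65 nM.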

Compound 3, dissociation constant: 33.8 nM
The estimate for compound 3 lay 1.7-fold (0.23 log units) below the measured number, within the range that was stated.
By their numbers in this assay, from the lowest: compounds 2 and 3 (each within the scatter of the next); then compound 1.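

Within the data shown here, this is the first measured change on the phenyl on the far side of the shared core: in this assay, chloro in place of hydrogen, para to a large group, gives a 1.7-fold higher number from compound 2 to compound 3 (0.24 log units; within the scatter), so phenyl and 4-chlorophenyl cannot be told apart here. No measurement available explains this result.

Still open, as far as these compounds go, is whether another group at this place, such as methoxy or an amine, would move the number beyond the scatter. Also open, from the compounds shown here alone, is whether chloro would behave the same way alongside the 4-methylphenyl of compound 1.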